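The source may report more compounds than this note shows. Statements on the series, on what has been measured and on what is new or still open speak of the compounds shown alone.

Compound 1 `O=C1C(Nc2ccc(I)cc2)=CC(=O)c2c1nc1n2[C@H]2OC[C@@H](O)[C@H]2OC1`: 4010 nM
Compound 2 `O=C1C(Nc2ccccc2F)=CC(=O)c2c1nc1n2[C@H]2OC[C@@H](O)[C@H]2OC1`: 9820 nM
Compound 3 `O=C1C(NCc2ccccc2)=CC(=O)c2c1nc1n2[C@H]2OC[C@@H](O)[C@H]2OC1`: 11000 nM

These three compounds share one core and differ only in the group on the amine nitrogen. All were tested in a functional assay on HeLa cells (Homo sapiens) for inhibition, read by sulforhodamine B assay; on this read-out higher numbers stand for weaker inhibition and lower numbers for stronger inhibition. The number for compound 3 cannot be told apart from that of its nearest neighbour, a 1.1-fold higher number from compound 2 to compound 3 (0.05 log units; within the scatter). The gap to its furthest neighbour is real but modest, a 2.7-fold higher number from compound 1 to compound 3 (0.44 log units; beyond the scatter).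

The next compound, compound 4 `CCCN(CCC)C1=CC(=O)c2c(nc3n2[C@H]2OC[C@@H](O)[C@H]2OC3)C1=O`, has not yet been measured. It carries dipropylamino in place of benzylamino on a double-bonded ring carbon, (dipropylamino in place of benzylamino on a double-bonded ring carbon).

Among the compounds with values here, the steps that bear on this change are those between the groups on that same nitrogen. Besides the two above, there is a 2.4-fold higher number from compound 1 to compound 2 (0.39 log units; beyond the scatter). Each is modest at most, but each swaps one ring-bearing group for another. Within the data shown here, the data therefore hold no direct precedent for an open-chain group, or for a nitrogen without its hydrogen, and the range must stay wide.

With steps reaching only a 2.7-fold higher number from compound 1 to compound 3 (0.44 log units; beyond the scatter), no clear shift in either direction is expected, and the estimated step is a 1.1-fold lower number from compound 3 to compound 4 (0.04 log units; within the scatter). The expected value for compound 4 is 10000 nM. The estimated range for it runs from 3500 nM to 30000 nM.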

Compound 4, half-maximal inhibitory concentration: > 16000 nM
Compound 4 gave a limit, no number; the forecaster's own chance of this, stated with the estimate: 10%; middle value at least 1.6-fold (0.20 log units) away from the limit.
By their numbers in this assay, from the lowest: compound 1; then compounds 2 and 3 (each within the scatter of the next). At a limit, above all of these: compound 4.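

In this assay, compound 4 gave only a limit, not a number: the limit of > 16000 nM in this assay, at which 1 of the 4 values shown sits. Within the data shown here, the one step that clears the scatter is an at least 3.9-fold higher number from compound 1 to compound 4 (0.60 log units; beyond the scatter), so on this double-bonded ring carbon, dipropylamino gives weaker inhibition than (4-iodophenyl)amino. The other two steps are floors, an at least 1.4-fold higher number from compound 3 to compound 4 (0.16 log units; that floor lies within the scatter) and an at least 1.6-fold higher number from compound 2 to compound 4 (0.21 log units; that floor lies within the scatter), so the order against those two neighbours stays unsettled, yet the change from a ring-bearing group with a hydrogen on its nitrogen to an open-chain group without one brings no stronger inhibition in any of the three comparisons.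

Dipropylamino differs from the earlier groups by having no ring and no hydrogen-bond donor, and this single compound cannot show which of the two differences matters, or how far its true value lies past the limit. A propylamino group would keep the open chain along with the hydrogen on the nitrogen, while a piperidine ring would restore a ring on a nitrogen without that hydrogen, and the compounds shown include neither.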